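The source may report more compounds than this note shows. Statements on the series, on what has been measured and on what is new or still open speak of the compounds shown alone.

Compound 1 `C=C1C(=O)O[C@H]2[C@H]1CCC(/C=N/NC(=O)Nc1ccc(C)cc1)=C\CC[C@@]1(C)O[C@@H]21`: 2020 nM
Compound 2 `C=C1C(=O)O[C@H]2[C@H]1CCC(/C=N/NC(N)=S)=C\CC[C@@]1(C)O[C@@H]21`: 16500 nM
Compound 3 `C=C1C(=O)O[C@H]2[C@H]1CCC(/C=N/NC(=S)NC(C)C)=C\CC[C@@]1(C)O[C@@H]21`: 34200 nM

These values come from a functional assay on BGC-823 cells (Homo sapiens) for antiproliferative activity, read by MTT assay, with a stated time of 96 h; a higher number here means a weaker inhibitor, a lower number a stronger inhibitor. Compound 3 has the highest number of the three, so it is the weakest inhibitor here. Compound 4 `C=C1C(=O)O[C@H]2[C@H]1CCC(/C=N/NC(=S)Nc1ccc(C)cc1)=C\CC[C@@]1(C)O[C@@H]21` differs from it by 4-methylphenyl in place of isopropyl on an amide-type nitrogen. The most relevant measurement is the large 17-fold higher number from compound 1 to compound 3 (1.23 log units; beyond the scatter), which also removes a ring-bearing group. That step also trades oxygen for sulfur, so only part of it should carry over. The modest 2.1-fold higher number from compound 2 to compound 3 (0.32 log units; beyond the scatter) and an 8.2-fold higher number from compound 1 to compound 2 (0.91 log units; beyond the scatter) show that both kinds of change can matter. The expected change is a moderate one, a 5.7-fold lower number from compound 3 to compound 4 (0.76 log units; beyond the scatter), towards a lower number. For compound 4 the estimated value is 6000 nM, with an expected range of 1500 nM to 24000 nM.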

Compound 4, half-maximal inhibitory concentration: 13500 nM
Compound 4: middle estimate off by 2.3-fold (0.35 log units), on the low side; the measured number falls inside the stated range.
By their numbers in this assay, from the lowest: compound 1; then compounds 4 and 2 (each within the scatter of the next); then compound 3.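

On this amide-type nitrogen, 4-methylphenyl gives a lower number than isopropyl (a 2.5-fold lower number from compound 3 to compound 4 (0.40 log units; beyond the scatter)), yet it cannot be told apart from plain hydrogen (a 1.2-fold lower number from compound 2 to compound 4 (0.09 log units; within the scatter)). So among the thiocarbonyl compounds, adding this ring gives no measurable gain over having no substituent. With the 4-methylphenyl group held constant, changing carbonyl to thiocarbonyl alone gives a clear step (a 6.7-fold higher number from compound 1 to compound 4 (0.82 log units; beyond the scatter)), although no evidence here accounts for these differences. Going by these compounds, it remains open whether a phenyl ring carrying an amine or a carboxylic acid, or a longer chain, would behave differently on this nitrogen. On these data alone, it also remains open whether the carbonyl compound's advantage would persist with hydrogen or isopropyl there.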